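The source may hold more compounds than are shown below. What is called first, only, known or untested is meant among the compounds shown, and "the series" means these compounds.

Measured so far in a functional assay on HCT-116 cells (Homo sapiens) for cytotoxicity, read by MTT assay, with a stated time of 72 h; a higher number here means a weaker inhibitor, a lower number a stronger inhibitor:

Compound 1 `O=C1C=CCC/C1=C\C=C\c1ccccc1`: 5400 nM
Compound 2 `Cc1ccc(/C=C/C=C2\CCC=CC2=O)cc1`: 7200 nM

Going by the values given here, compound 2 stands within the scatter of compound 1, the only other compound measured, so the two cannot be ranked. The next compound is compound 3 `O=C1C=CCC/C1=C\C=C\c1ccc(F)cc1`, reached from compound 2 by fluoro in place of methyl on an aromatic carbon. Among the compounds with values here, one measured step bears on this change: methyl in place of hydrogen on an aromatic carbon, a 1.3-fold higher number from compound 1 to compound 2 (0.12 log units; within the scatter), which stays within the scatter. Within the data shown here, no measured compound carries fluoro, so the data give no direct reading on that group. Given the small size of that single step, no change beyond the scatter is expected in this assay. The expected step is a 1.3-fold lower number from compound 2 to compound 3 (0.12 log units; within the scatter), an estimate within the scatter. For compound 3 the estimated value is 5500 nM, with an expected range from 2800 nM to 11000 nM.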

Compound 3, half-maximal inhibitory concentration: 2200 nM
Compound 3: the middle estimate sits 2.5-fold (0.40 log units) above what was measured, outside the stated range (below it).
By their numbers in this assay, from the lowest: compound 3; then compounds 1 and 2 (each within the scatter of the next).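

At this position, on an aromatic carbon para to a large group, the earlier pair had shown only a step within the scatter, whereas fluoro gives the first steps beyond it in this assay: a 3.3-fold lower number from compound 2 to compound 3 (0.51 log units; beyond the scatter), and a 2.5-fold lower number from compound 1 to compound 3 (0.39 log units; beyond the scatter), both modest. The position therefore responds to what it carries, with fluoro standing apart from both hydrogen and methyl, two groups that cannot be ranked against each other here. No available evidence accounts for this difference.

On these data alone, whether the lower number is particular to fluoro remains open, since chloro, methoxy or a nitrile at the same position could show either a similar or a different result. Also unresolved is whether fluoro would give a comparable step elsewhere on the aromatic ring, or with changes to the shared core.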